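The source may report more compounds than this note shows. Statements on the series, on what has been measured and on what is new or still open speak of the compounds shown alone.

Three compounds have been measured in a functional assay on SNB-19 cells (Homo sapiens) for inhibition, read by sulforhodamine B assay, with a stated time of 48 h; a higher number here means a weaker inhibitor of growth, a lower number a stronger inhibitor of growth:

Compound 1 `COc1ccc2[nH]c(-c3ccccc3)c(C=C(C#N)C#N)c2c1`: 6000 nM
Compound 2 `COc1ccc(-c2[nH]c3ccc(OC)cc3c2C=C(C#N)C#N)cc1`: 13700 nM
Compound 3 `COc1ccc2[nH]c(-c3ccccc3)c(/C=C(\C#N)S(=O)(=O)c3ccccc3)c2c1`: 13500 nM

Compound 3 and compound 2 sit close together, while compound 1 stands apart. The change from compound 2 to compound 1 is hydrogen in place of methoxy on an aromatic carbon, and it gave a 2.3-fold lower number from compound 2 to compound 1 (0.36 log units; beyond the scatter). Going by these compounds, compound 4 `N#C/C(=C\c1c(-c2ccccc2)[nH]c2ccccc12)S(=O)(=O)c1ccccc1` is untested; it differs from compound 3 by hydrogen in place of methoxy on an aromatic carbon. The difference between the core of compound 3 and that of compound 2 is not broken down here. The two changes are the same kind of change, not the same: in compound 2 the methoxy sits para to a large group, in compound 3 it sits meta and para to a fused ring. Within the data shown here, a step of similar direction is expected, a 1.5-fold lower number from compound 3 to compound 4 (0.18 log units; within the scatter), resting only on the single earlier step of a 2.3-fold lower number from compound 2 to compound 1 (0.36 log units; beyond the scatter). Compound 4 is therefore estimated at 9000 nM, between 3000 nM and 27000 nM.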

Compound 4, concentration for 50% growth inhibition: 8300 nM
For compound 4 the middle estimate is 1.1-fold (0.04 log units) above the measured one, and the stated range covers the measured number.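

In this assay replacing methoxy with hydrogen gave a 1.6-fold lower number from compound 3 to compound 4 (0.21 log units; within the scatter) and so, taken alone, this step is no clear change. Set beside the earlier case, the two steps agree: the same change on two cores in this assay, a 2.3-fold lower number (0.36 log units; beyond the scatter) from compound 2 to compound 1 and a 1.6-fold lower number (0.21 log units; within the scatter) from compound 3 to compound 4, 1.4-fold (0.15 log units) apart, within the scatter of two such steps. The change therefore carried from one core to the other with no detectable difference in the size of its step, but two pairs cannot show that it would do so on other cores in this series, nor why the steps have the size they do.

The compounds shown leave open what a hydroxyl group, a fluorine atom or an amine would do in place of the methoxy. They also leave open how a longer chain, such as ethoxy, would fare there.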